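A few compounds are considered here, and "the series" means these few. Any claim that something is new, unique, unknown or untested is made for them only; others in the source may bear on it.

Working notes on the esters of the shared core. Compound 1 `CC1=CC[C@H](C(C)C)c2cc(C)c(OC(=O)c3ccccc3)cc21` in a functional assay on K562 cells (Homo sapiens) for antiproliferative activity, read by sulforhodamine B assay, with a stated time of 48 h, tested at 50 uM (on this read-out lower numbers stand for less inhibition and higher numbers for more inhibition at the one concentration tested (going by the name of the read-out)), is recorded as "not active" (no number reported), with no number given. Compound 2 `CC1=CC[C@H](C(C)C)c2cc(C)c(OC(=O)c3ccc(C(F)(F)F)cc3)cc21` in this assay gives 9%. Within the data shown here, compound 3 `CC1=CC[C@H](C(C)C)c2cc(C)c(OC(=O)c3cccc(C)c3)cc21`, carrying the 3-methylphenyl group, is likewise recorded in this assay as "not active" (no number reported); compound 3 thus stands with no figure at all, in the same position as compound 1, while compound 2 is the only member with a number, and a small one. Among the measured compounds shown here, no steps between measured pairs are computed. Compound 4 `COc1ccc(C(=O)Oc2cc3c(cc2C)[C@@H](C(C)C)CC=C3C)cc1` is the next ester and has not been measured in this assay. It differs from compound 3 by 4-methoxyphenyl in place of 3-methylphenyl on a carbonyl carbon. With compound 1 and compound 3 both without a number and compound 2 at 9%, nothing here points to appreciable inhibition, and no step beyond the scatter is expected in this assay from compound 3 to compound 4 in either direction. Compound 4 is estimated to give 5% in this assay, within 0% to 15%, with a fair chance that no number is reported.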

Compound 4, a percentage reported as inhibition, at one concentration (the size of the read-out at that concentration, not a potency): 46.5%
The estimate for compound 4 lay 41.5 percentage points below the measured number; measured number above the stated range.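

In this assay, the group on the carbonyl carbon can decide the read-out: methoxy in place of trifluoromethyl on an aromatic carbon gives a number 37.5 percentage points higher from compound 2 to compound 4 (beyond the scatter). Compound 3 is recorded as "not active" (no number reported) while compound 4 gives 46.5%, so esters of the shared core are not uniformly weak at the one concentration tested, although steps from compound 1 and compound 3 cannot be read without a number. Nothing available bears on what lies behind this difference.

Open, on these data alone, is whether the result is specific to methoxy or would hold with a hydroxyl, an ethoxy or a dimethylamino group in its place. A single-concentration percentage also leaves the potency of compound 4 open.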